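This account rests on a few compounds, and the source may have more. Where it says the series, first, only, none or still open, it means among the compounds named here.

Compound 1 `Cc1oc(C(=O)O)cc1COc1ccc(-c2ccc(Cl)cc2)cc1` gives 1000 nM in an assay on cells for displacement of a labelled ligand from prostaglandin E2 receptor EP4 subtype (Homo sapiens), read by scintillation counting; on this read-out lower numbers stand for stronger inhibition and higher numbers for weaker inhibition.
Compound 2 `CC(=O)c1ccc(-c2ccc(OCc3cc(C(=O)O)oc3C)cc2)cc1` gives 150 nM in this assay.
Compound 3 `COc1ccc(-c2ccc(OCc3cc(C(=O)NS(=O)(=O)c4cccs4)oc3C)cc2)cc1` gives 3.6 nM in this assay.

Compound 3 stands lowest of the three numbers in this assay: compound 2 is nearest, with a value that is clearly higher, and compound 1 is furthest. Compound 2 and compound 3 differ in more than one place, so their two values are simply noted side by side.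

Compound 4 `COc1ccc(-c2ccc(OCc3cc(C(=O)NS(=O)(=O)c4ccc(CN)cc4)oc3C)cc2)cc1` is derived from compound 3 by one change: 4-(aminomethyl)phenyl in place of thiophen-2-yl on a sulfonyl sulfur. Among the measured compounds shown here, the only single-place step measured so far, a 6.7-fold lower number from compound 1 to compound 2 (0.82 log units; beyond the scatter), concerns the other end of the molecule, a group on the distant aromatic ring, and says nothing about the sulfonyl side. For the measured compounds named here, there is therefore no measured step that bears directly on this change, and nothing in the data argues for a large shift in either direction in this assay. The expectation is a step around the scatter, a 1.7-fold higher number from compound 3 to compound 4 (0.22 log units; within the scatter), so compound 4 is estimated at 6 nM, with a plausible range from 1.5 nM to 25 nM.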

Compound 4, inhibition constant: 100 nM
Compound 4: the middle estimate sits 17-fold (1.22 log units) below what was measured; measured number outside the range, above it.
By their numbers in this assay, from the lowest: compound 3; then compounds 4 and 2 (each within the scatter of the next); then compound 1.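

The group on the sulfonyl sulfur turns out to matter a great deal: in this assay, replacing thiophen-2-yl with 4-(aminomethyl)phenyl gives a 28-fold higher number from compound 3 to compound 4 (1.44 log units; beyond the scatter), a large weakening well beyond the scatter. Among the compounds shown here, the only earlier single-place step, a 6.7-fold lower number from compound 1 to compound 2 (0.82 log units; beyond the scatter), concerned acetyl in place of chloro on an aromatic carbon, so this is the first measured sign of how sensitive the sulfonyl side is. Nothing available explains why the number rises so sharply.

This single swap changes both the ring and its aminomethyl group, so a plain phenyl on the sulfonyl sulfur would be needed to tell which of the two goes with the weakening. Also open, as far as these compounds go, is how other groups there, such as a methyl or a longer alkyl chain, would behave.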